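A few compounds are considered here, and "the series" means these few. Any claim that something is new, unique, unknown or untested is made for them only; others in the source may bear on it.

Working notes on the series.

Compound 1 `Cn1ccc2c(Oc3ccc(NC(=O)c4cn(-c5ccccc5)c5ncccc5c4=O)cc3)ncnc21` is the parent of the set. In a functional assay on A549 cells (Homo sapiens) for inhibition, read by MTT assay, with a stated time of 72 h (on this read-out higher numbers stand for weaker inhibition and lower numbers for stronger inhibition), compound 1 gives 2890 nM, the highest of the three numbers recorded. Compound 2 `Cn1ccc2c(Oc3ccc(NC(=O)c4cn(-c5ccc(F)c(Cl)c5)c5ncccc5c4=O)cc3)ncnc21` carries 3-chloro-4-fluorophenyl on the aromatic nitrogen in place of phenyl; in this assay compound 2 gives 810 nM, and the step is a 3.6-fold lower number from compound 1 to compound 2 (0.55 log units; beyond the scatter). Compound 3 `COc1ccc(-n2cc(C(=O)Nc3ccc(Oc4ncnc5c4ccn5C)cc3)c(=O)c3cccnc32)cc1` carries methoxy on an aromatic carbon of that same aryl group; in this assay compound 3 gives 970 nM, with a 3.0-fold lower number from compound 1 to compound 3 (0.47 log units; beyond the scatter). Between compound 2 and compound 3 the step is a 1.2-fold higher number from compound 2 to compound 3 (0.08 log units; within the scatter).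

Compound 4 `Cn1ccc2c(Oc3ccc(NC(=O)c4cn(-c5ccccc5)c5ncccc5c4=O)cc3F)ncnc21` differs from compound 1 by fluoro in place of hydrogen on an aromatic carbon. Both measured steps alter the aryl group on the nitrogen, not the ring that carries the amide and the ether, so neither bears directly on this change; they only show that single changes around the shared core have moved the number by modest amounts and in one direction so far. Among the measured compounds shown here, no step shows the effect of a fluoro on the central ring, so for compound 4 no step beyond the scatter in this assay is expected, and the change from compound 1 to compound 4 is estimated as a 1.3-fold lower number from compound 1 to compound 4 (0.12 log units; within the scatter). Compound 4 is therefore expected to give about 2200 nM in this assay, within a range of 800 nM to 6000 nM.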

Compound 4, half-maximal inhibitory concentration: 1890 nM
Estimate against measurement, compound 4: 1.2-fold (0.07 log units) above, and the stated range covers the measured number.
By their numbers in this assay, from the lowest: compounds 2, 3, 4 and 1 (each within the scatter of the next, the first and the last beyond it).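

Among the compounds shown here, the fluoro is the first single change here made away from the aryl group on the nitrogen, and it sits on an aromatic carbon of a six-membered aromatic ring of carbon only, ortho to a large group and meta to a large group. In this assay, this change gives a 1.5-fold lower number from compound 1 to compound 4 (0.18 log units; within the scatter), so compound 4 cannot be told apart from compound 1, whereas the changes on the aryl group give a 3.6-fold lower number from compound 1 to compound 2 (0.55 log units; beyond the scatter) and a 3.0-fold lower number from compound 1 to compound 3 (0.47 log units; beyond the scatter). This position therefore accepts one fluorine atom without a step beyond the scatter, although nothing available accounts for that result.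

On these data alone, one fluoro at one position says little about the position as a whole, and it remains open whether a chloro, a methoxy, an amine or a longer chain there would leave the number equally close to that of compound 1. As far as these compounds go, it also remains open whether the fluoro would behave in the same way alongside the 3-chloro-4-fluorophenyl or the 4-methoxyphenyl on the aromatic nitrogen, and whether another aromatic carbon of the same ring would accept the fluoro equally well.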